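Phenyl for Methyl on the Amide Chain of Compound 3

The source may hold more compounds than are shown below. What is called first, only, known or untested is meant among the compounds shown, and "the series" means these compounds.

Measured so far:
Compound 1, `CC(=O)Oc1ccc(-c2ccc(F)cc2F)cc1C(=O)O`: 13.7%
Compound 2, `O=C(Oc1ccc(-c2ccc(F)cc2F)cc1C(=O)O)c1ccccc1`: 16.1%
Compound 3, `CCNC(=O)c1cc(-c2ccc(F)cc2F)ccc1OC(C)=O`: 5.38%

In a functional assay on the whole organism (Ear) for inhibition, with Mus musculus as the target, at a dose of 40 mg/kg by the oral route (a higher number here means more inhibition at the dose given (going by the name of the read-out), a lower number less inhibition), compound 3 holds the lowest of the three numbers: its gap to compound 1 is within the scatter, a number 8.3 percentage points lower from compound 1 to compound 3 (within the scatter), while its gap to compound 2 lies beyond it. Compound 4, `CC(=O)Oc1ccc(-c2ccc(F)cc2F)cc1C(=O)NCc1ccccc1`, differs from compound 3 by phenyl in place of methyl on a saturated chain carbon bound to an amide-type nitrogen. Within the data shown here, the one measured step of the same kind, phenyl in place of methyl on a carbonyl carbon, gave a number 2.4 percentage points higher from compound 1 to compound 2 (within the scatter). On that basis no step beyond the scatter is expected in this assay, in either direction. Compound 4 is therefore estimated to give 8%, with a range from 0% to 20%. The expected step is a number 2.6 percentage points higher from compound 3 to compound 4 (within the scatter).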

Compound 4, a percentage reported as inhibition, in the whole organism at one dose (the size of the read-out at that dose, not a potency): 34.1%
For compound 4 the middle estimate is 26.1 percentage points below the measured one; measured number outside the range, above it.
By their numbers in this assay, from the lowest: compounds 3, 1 and 2 (each within the scatter of the next, the first and the last beyond it); then compound 4.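

In this assay the amide chain turns out to be a place where this change counts: a number 28.7 percentage points higher from compound 3 to compound 4 (beyond the scatter) follows from phenyl in place of methyl there, while a number 2.4 percentage points higher from compound 1 to compound 2 (within the scatter) is all the same exchange gave on the carbonyl carbon. Benzylamino in place of hydroxy also clears the scatter, with a number 20.4 percentage points higher from compound 1 to compound 4 (beyond the scatter) as its step, which ethylamino did not do. Nothing measured here accounts for the gain.

Open, as far as these compounds go, is whether a longer chain, such as phenethylamino, or a pyridyl ring in place of the phenyl would hold this level. Also open, from the compounds shown here alone, is whether benzoyl in place of acetyl would add to the benzylamino step.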